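The compounds below may be only part of what the source reports. "The series", "measured", "known", "first", "only" and "open" are said of these compounds alone.

Measured in a toxicity assay on HepG2 2.2.15 cells (Homo sapiens) for cytotoxicity, read by CellTiter-Glo; a higher number here means that more compound is tolerated, a lower number that less compound is tolerated:
compound 1 `O=C1OC(c2ccccc2)CN1c1cnn2c1CN(C(=O)Nc1cc(F)c(F)c(F)c1)C(C1CC1)C2`: 7410 nM
compound 2 `O=C1CC(c2ccccn2)CN1c1cnn2c1CN(C(=O)Nc1cc(F)c(F)c(F)c1)C(C1CC1)C2`: 96200 nM

Compound 2 holds the higher of the two numbers, and its gap to compound 1 lies beyond the scatter. Compound 3 `Cc1nc(C2CC(=O)N(c3cnn4c3CN(C(=O)Nc3cc(F)c(F)c(F)c3)C(C3CC3)C4)C2)no1` keeps the rest of compound 2 and carries 5-methyl-1,2,4-oxadiazol-3-yl in place of pyridin-2-yl on a saturated ring carbon. Among the compounds with values here, only one measured step bears on this change. That step, a 13-fold higher number from compound 1 to compound 2 (1.11 log units; beyond the scatter), is large, but it exchanges the whole 2-oxo-5-phenyl-1,3-oxazolidin-3-yl for 2-oxo-4-(pyridin-2-yl)pyrrolidin-1-yl. Within the data shown here, no measured step isolates the loss of pyridin-2-yl alone, so a step of that size is not carried over to this assay here. The expected step is a 1.4-fold lower number from compound 2 to compound 3 (0.14 log units; within the scatter), with no expected change beyond the scatter. Compound 3 is estimated at 70000 nM, with an expected range of 20000 nM to 150000 nM.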

Compound 3, half-maximal cytotoxic concentration: > 200000 nM
Compound 3: only a limit was reported (the forecaster's own chance of this, stated with the estimate: 35%); at least 2.8-fold (0.45 log units) between middle value and limit.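

Replacing pyridin-2-yl with 5-methyl-1,2,4-oxadiazol-3-yl on the saturated ring carbon gives an at least 2.0-fold higher number from compound 2 to compound 3 (0.31 log units; beyond the scatter) in this assay, the only step shown that is confined to this position. Compound 3 carries a limit of the assay, not a number: the limit of > 200000 nM in this assay, at which 1 of the 3 values shown sits. The full exchange of 2-oxo-5-phenyl-1,3-oxazolidin-3-yl for 4-(5-methyl-1,2,4-oxadiazol-3-yl)-2-oxopyrrolidin-1-yl gives an at least 26-fold higher number from compound 1 to compound 3 (1.43 log units; beyond the scatter), so the group on this ring carbon still moves the number with the 2-oxopyrrolidin-1-yl ring kept in place.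

Going by these compounds, how far compound 3 lies past its limit stays open. Also open, on these data alone, is whether the number depends on an aromatic ring at this position at all, which a primary amine, a carboxylic acid or a plain methyl group on the same ring carbon would test.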